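Extending the Alkoxyamide Tail of Compound 2

The source may hold more compounds than are shown below. What is called first, only, known or untested is meant among the compounds shown, and "the series" means these compounds.

Compound 2 `CCONC(=O)[C@H]1OC(n2cnc3c(N)ncnc32)[C@H](O)[C@@H]1O` gives 67 nM in an assay on cell membranes for binding affinity to 2-oxoglutarate receptor 1 (Rattus norvegicus), read by radioligand binding (a lower number here means a stronger inhibitor, a higher number a weaker inhibitor), the higher of the two numbers shown. Compound 1 `Nc1ncnc2c1ncn2C1O[C@H](C(=O)NC2CCCCCCC2)[C@@H](O)[C@H]1O` gives 23 nM in this assay. For the measured compounds named here, the one measured step bearing on this position, a 2.9-fold higher number from compound 1 to compound 2 (0.46 log units; beyond the scatter), accompanied a change from cyclooctyl to ethoxy on the amide-type nitrogen. Compound 3 `CC(C)CONC(=O)[C@H]1OC(n2cnc3c(N)ncnc32)[C@H](O)[C@@H]1O` carries isopropyl in place of methyl on a saturated chain carbon bound to an oxygen on an unsaturated carbon, lengthening that alkoxy group again, though this is not the same change in reverse. Compound 3 is therefore expected to show a modest fall in the number, estimated at 40 nM with a range of 15 nM to 110 nM, a step of a 1.7-fold lower number from compound 2 to compound 3 (0.22 log units; within the scatter).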

Compound 3, inhibition constant: 20 nM
For compound 3 the middle estimate is 2.0-fold (0.30 log units) above the measured one; the measured number falls inside the stated range.
By their numbers in this assay, from the lowest: compounds 3 and 1 (each within the scatter of the next); then compound 2.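

Replacing ethoxy with isobutoxy on the amide-type nitrogen lowered the number in this assay (a 3.4-fold lower number from compound 2 to compound 3 (0.53 log units; beyond the scatter)), so this position responds to a larger branched alkoxy group. The open-chain isobutoxy amide also matches the cyclooctyl amide (a 1.2-fold lower number from compound 1 to compound 3 (0.06 log units; within the scatter)), which shows that a ring on that nitrogen is not required for this level of binding. Nothing available explains the gain. The compounds shown leave open whether a longer chain on the oxygen would lower the number further, and how an alkoxy group ending in an amine or a carboxylic acid would behave.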